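Cinnamylidene Imine Replaces Dichlorophenyl: Cytotoxicity Estimate

This account rests on a few compounds, and the source may have more. Where it says the series, first, only, none or still open, it means among the compounds named here.

Measured compounds and their values:
compound 1 `Clc1ccc(/C=N/c2sc3c(c2-c2nc4ccccc4s2)CCC3)cc1`, 342 ug/mL
compound 2 `Clc1ccccc1/C=N/c1sc2c(c1-c1nc3ccccc3s1)CCC2`, 123 ug/mL
compound 3 `Clc1ccc(/C=N/c2sc3c(c2-c2nc4ccccc4s2)CCC3)c(Cl)c1`, 160 ug/mL

In an ADME assay on cells (Rhabdomyosarcoma cell, Homo sapiens) for cytotoxicity, read by MTT assay, with a stated time of 72 h (on this read-out lower numbers stand for higher toxicity in this test and higher numbers for lower toxicity in this test), compound 3 gives 160 ug/mL, the second highest of the three numbers; its nearest neighbour is compound 2, and the gap a 1.3-fold higher number from compound 2 to compound 3 (0.11 log units; within the scatter) lies within the scatter, while the step of a 2.1-fold lower number from compound 1 to compound 3 (0.33 log units; beyond the scatter) lies beyond it. Compound 4 `C(=C/c1ccccc1)\C=N\c1sc2c(c1-c1nc3ccccc3s1)CCC2` differs from compound 3 by 2-phenylethenyl in place of 2,4-dichlorophenyl on a carbon with a double bond to nitrogen. Going by the values given here, no measured step exchanges an aromatic ring for a 2-phenylethenyl group; the steps of a 2.8-fold lower number from compound 1 to compound 2 (0.44 log units; beyond the scatter) and a 2.1-fold lower number from compound 1 to compound 3 (0.33 log units; beyond the scatter) only move or add chlorine and bear on this change indirectly. Compound 4 is therefore expected to stay close to compound 3, with a 1.3-fold higher number from compound 3 to compound 4 (0.10 log units; within the scatter) as the estimated step. Compound 4 is estimated at 200 ug/mL, within 80 ug/mL to 500 ug/mL.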

Compound 4, half-maximal cytotoxic concentration: 122 ug/mL
Beside the measured number, compound 4's estimate is 1.6-fold (0.21 log units) above it; low and high end bracket the measured number.
By their numbers in this assay, from the lowest: compounds 4, 2 and 3 (each within the scatter of the next); then compound 1.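

In this assay, the carbon with a double bond to nitrogen carries 2-phenylethenyl, which has no chlorine, and the number stays level with two chlorinated compounds: a 1.3-fold lower number from compound 3 to compound 4 (0.12 log units; within the scatter) and a 1.0-fold lower number from compound 2 to compound 4 (0.00 log units; within the scatter) both lie within the scatter. Only a 2.8-fold lower number from compound 1 to compound 4 (0.45 log units; beyond the scatter) lies beyond it, so compound 1 alone stands apart among the four compounds. Nothing at hand explains this result.

Open, from the compounds shown here alone, is whether a plain phenyl group, a saturated 2-phenylethyl chain or a carboxylic acid at this carbon would stay within this range.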